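This account rests on a few compounds, and the source may have more. Where it says the series, first, only, none or still open, it means among the compounds named here.

Compound 1 `CCCn1c(-c2ccc(O)c(O)c2)c(C)c2cc(O)ccc21`: > 20000 nM
Compound 2 `Cc1c(-c2ccc(O)cc2)[nH]c2ccccc12`: > 20000 nM

In a functional assay on HeLa cells (Homo sapiens) for inhibition, read by trypan blue exclusion, with a stated time of 72 h (a lower number here means a stronger inhibitor of growth, a higher number a weaker inhibitor of growth), compound 1 shows only a limit of the assay, not a number. Compound 2 likewise shows only a limit of the assay in this assay. Both values sit at the limit of > 20000 nM in this assay, at which 2 of the 2 values shown sit. Compound 3 `Cc1c(-c2ccc(O)c(O)c2)n(C)c2ccc(O)cc12` differs from compound 1 by hydrogen in place of ethyl on a saturated chain carbon bound to an aromatic nitrogen. Among the compounds with values here, no measured step of this kind is available, and compound 1 itself sits at the limit of > 20000 nM in this assay, at which 2 of the 2 values shown sit, so the expected step is a step that the limit leaves unreadable from compound 1 to compound 3, that is, none beyond the usual scatter. Compound 3 is therefore expected to give about 25000 nM in this assay, within 8000 nM to 80000 nM.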

Compound 3, concentration for 50% growth inhibition: > 20000 nM
Compound 3 gave a limit, no number; the forecaster's own chance of this, stated with the estimate: 70%; the middle value lies beyond the limit too.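

Compound 1 and compound 3 both give only a limit in this assay, so no step between them can be read: the limit of > 20000 nM in this assay, at which 3 of the 3 values shown sit.

The compounds shown leave open how strongly any of them inhibits growth, and whether propyl or methyl makes any difference.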